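The compounds below may be only part of what the source reports. "The series", "measured", "known", "first", "only" and "open" are said of these compounds alone.

In a functional assay on HeLa cells (Homo sapiens) for cytotoxicity, read by MTT assay (a lower number here means a stronger inhibitor, a higher number a weaker inhibitor), compound 1 `CCCCC(O)CC(=O)O[C@H](CC=C(C)C)C1=CC(=O)c2c(O)ccc(O)c2C1=O` gives 72200 nM, and compound 2 `CCCCC(CC(=O)O[C@H](CC=C(C)C)C1=CC(=O)c2c(O)ccc(O)c2C1=O)OC(C)=O` gives 73500 nM. Compound 2 holds the higher of the two numbers, though the gap to compound 1 is within the scatter: a 1.0-fold higher number from compound 1 to compound 2 (0.01 log units; within the scatter). Compound 3 `CCCC(CC(=O)O[C@H](CC=C(C)C)C1=CC(=O)c2c(O)ccc(O)c2C1=O)OC(C)=O` differs from compound 2 by hydrogen in place of methyl on a saturated chain carbon, four bonds along the chain from an oxygen next to a carbonyl group. Among the measured compounds shown here, no measured step touches this part of the chain; the only step known, from compound 1 to compound 2, changed nothing beyond the scatter. The expectation for compound 3 is therefore a step of about a 1.0-fold lower number from compound 2 to compound 3 (0.00 log units; within the scatter). Compound 3 is estimated at 73000 nM, within a range from 35000 nM to 150000 nM.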

Compound 3, half-maximal inhibitory concentration: 51200 nM
Beside the measured number, compound 3's estimate is 1.4-fold (0.15 log units) above it; measured number inside the range.
By their numbers in this assay, from the lowest: compounds 3, 1 and 2 (each within the scatter of the next).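

Removing the methyl group, four bonds along the chain from an oxygen next to a carbonyl group, gives a 1.4-fold lower number from compound 2 to compound 3 (0.16 log units; within the scatter) in this assay. So the first change to the chain's length leaves the number within normal repeat variation, as does the swap of 1-hydroxypentyl for 1-acetoxybutyl, which gives a 1.4-fold lower number from compound 1 to compound 3 (0.15 log units; within the scatter). Nothing available offers a reason for either result. Still open, on these data alone, is whether a longer chain, or an amine in place of this methyl, would move the number beyond that variation.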